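From methyl to trifluoromethoxy in the sulfonyl series

A few compounds are considered here, and "the series" means these few. Any claim that something is new, unique, unknown or untested is made for them only; others in the source may bear on it.

In a functional assay on HepG2 cells (Homo sapiens) for inhibition, read by sulforhodamine B assay, with a stated time of 74 h (a lower number here means a stronger inhibitor, a higher number a weaker inhibitor), compound 1 `Cc1ccc(S(=O)(=O)N2C(=O)COC23C=CC(=O)C=C3)cc1` gives > 10000 nM, which is a limit of the assay and not a number. Compound 2 `O=C1C=CC2(C=C1)OCC(=O)N2S(=O)(=O)c1ccccc1` gives > 10000 nM, again only a limit. Among the compounds with values here, compound 3 `Cc1ccccc1S(=O)(=O)N1C(=O)COC12C=CC(=O)C=C2` gives 750 nM, the only true number in the set.

Compound 4 `O=C1C=CC2(C=C1)OCC(=O)N2S(=O)(=O)c1ccccc1OC(F)(F)F` keeps the shared core and carries trifluoromethoxy in place of methyl on an aromatic carbon, ortho to a large group (trifluoromethoxy in place of methyl on an aromatic carbon).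

Within the data shown here, two measured steps bear on this place: an at least 13-fold lower number from compound 1 to compound 3 (1.12 log units; beyond the scatter), and an at least 13-fold lower number from compound 2 to compound 3 (1.12 log units; beyond the scatter). Both are large, and both end at compound 3, so the measurable value goes with the 2-methylphenyl group on the sulfonyl sulfur. The step that the two limits leave unreadable from compound 1 to compound 2 adds no readable size. Among the measured compounds shown here, no measured step replaces the methyl of compound 3 with another group, so the size of this change remains untested.

Compound 4 keeps a group at the place where the step of an at least 13-fold lower number from compound 2 to compound 3 (1.12 log units; beyond the scatter) was seen, so it is expected to remain measurable in this assay. No step beyond the scatter is expected, with a slight lean towards a higher number: a 1.6-fold higher number from compound 3 to compound 4 (0.20 log units; within the scatter). The estimate for compound 4 is 1200 nM, with an expected range of 300 nM to 6000 nM.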

Compound 4, half-maximal inhibitory concentration: > 10000 nM
Compound 4 ended at the assay's limit; the forecaster's own chance of this, stated with the estimate: 12%; middle value at least 8.3-fold (0.92 log units) away from the limit.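

In this assay, within the data shown here, trifluoromethoxy in place of methyl on the aromatic carbon, ortho to a large group, gives an at least 13-fold higher number from compound 3 to compound 4 (1.12 log units; beyond the scatter), the first readable change of the group at this place rather than of where a methyl stands on the ring. Keeping a group at this place is therefore not enough to keep a measurable value, and among the compounds shown only the methyl of compound 3 gives one. Compound 4 now sits with compound 1 and compound 2 at a limit and not a number, so steps among these three cannot be read: the limit of > 10000 nM in this assay, at which 3 of the 4 values shown sit.

With a single measurable compound, the series does not show which feature of trifluoromethoxy separates it from methyl, nor how trifluoromethoxy compares with hydrogen at this place. On these data alone, whether the measurable value reaches beyond methyl stays open, and an ethyl, a methoxy or a chlorine atom at this place would help to show how narrow the tolerance is.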